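The source may report more compounds than this note shows. Statements on the series, on what has been measured and on what is new or still open speak of the compounds shown alone.

Among the measured compounds shown here, compound 3 `O=C(/C=C/c1ccc2c(c1)B(O)OC2)c1ccc(Br)cc1` gives 9500 nM in a functional assay on MDA-MB-231 cells (Homo sapiens) for cytotoxicity, read by MTT assay, with a stated time of 48 h (a higher number here means a weaker inhibitor, a lower number a stronger inhibitor), the second highest of the three numbers measured so far, beside compound 1 `O=C(/C=C/c1ccc2c(c1)B(O)OC2)c1cccnc1` with 11400 nM and compound 2 `O=C(/C=C/c1ccc2c(c1)B(O)OC2)c1ccc(Cl)cc1` with 7900 nM. All three values sit within the scatter of one another. Compound 4 `Cc1ccc(C(=O)/C=C/c2ccc3c(c2)B(O)OC3)cc1` differs from compound 3 by methyl in place of bromo on an aromatic carbon. The measured step that bears most directly on this change is a 1.2-fold higher number from compound 2 to compound 3 (0.08 log units; within the scatter), a halogen swap on an aromatic carbon; the exchanges of the whole ring on the carbonyl carbon, a 1.4-fold lower number from compound 1 to compound 2 (0.16 log units; within the scatter) and a 1.2-fold lower number from compound 1 to compound 3 (0.08 log units; within the scatter), were also within the scatter. For the measured compounds named here, no step seen so far moves the number beyond the scatter, so no shift beyond it is expected in this assay for the methyl group either. Compound 4 is therefore estimated at 9000 nM, with a range from 4500 nM to 18000 nM. The expected step is a 1.1-fold lower number from compound 3 to compound 4 (0.02 log units; within the scatter).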

Compound 4, half-maximal inhibitory concentration: 6500 nM
Estimate against measurement, compound 4: 1.4-fold (0.14 log units) above, and the stated range covers the measured number.
By their numbers in this assay, from the lowest: compounds 4, 2, 3 and 1 (each within the scatter of the next).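

In this assay, methyl on an aromatic carbon para to a large group shows a 1.5-fold lower number from compound 3 to compound 4 (0.16 log units; within the scatter) and also a 1.2-fold lower number from compound 2 to compound 4 (0.08 log units; within the scatter) when it replaces chloro, so this position tolerates a non-halogen group without a shift beyond the scatter. The change of the whole group on the carbonyl carbon shows a 1.8-fold lower number from compound 1 to compound 4 (0.24 log units; within the scatter) and likewise stays within the scatter. Nothing available explains the size of these steps. The compounds shown leave open whether an amine, a carboxylic acid or a longer chain at this position would move the number beyond the scatter.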